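The source may hold more compounds than are shown below. What is called first, only, known or untested is meant among the compounds shown, and "the series" means these compounds.

Measured in a functional assay on MCF7 cells (Homo sapiens) for inhibition, read by sulforhodamine B assay, with a stated time of 48 h, tested at 50 uM; a lower number here means less inhibition of growth, a higher number more inhibition of growth at the concentration tested:

Compound 1 `COc1ccc([C@@H]2CC(=O)c3cc(CC=C(C)C)c(OC)cc3O2)cc1`: 65%
Compound 2 `COc1ccc([C@@H]2C/C(=N/OCc3cn(-c4ccc(C#N)cc4)nn3)c3cc(CC=C(C)C)c(OC)cc3O2)cc1`: 40%
Compound 3 `COc1ccc([C@@H]2C/C(=N/OCc3cn(-c4ccc(Cl)cc4C)nn3)c3cc(CC=C(C)C)c(OC)cc3O2)cc1`: 37%

Compound 1, at 65%, stands highest of the three, and the other two lie clearly lower. Compound 4 `COc1cc2c(cc1CC=C(C)C)C(=O)C[C@@H](c1ccc(Oc3cccc([N+](=O)[O-])c3)cc1)O2` has not been measured yet. It keeps the core of compound 1 and changes one group: 3-nitrophenyl in place of methyl on an oxygen on an aromatic ring. Put simply, methoxy becomes 3-nitrophenoxy, so a single methyl gives way to a group that brings its own aromatic ring.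

Among the compounds with values here, the only measured step, a number 3 percentage points lower from compound 2 to compound 3 (within the scatter), is small and sits at a different place, on an aromatic nitrogen, so it says little about this change. Within the data shown here, no measured pair tests a change on this oxygen. Among the measured compounds shown here, the one weak guide is that compound 2, at 40%, and compound 3, at 37%, both carry large additions to the core and both read lower than compound 1. A moderate fall is therefore expected, with wide uncertainty. The estimated step is a number 17 percentage points lower from compound 1 to compound 4 (beyond the scatter). For compound 4 the expected value is 48%, with an estimated range from 25% to 72%.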

Compound 4, percent growth inhibition at one concentration: 53%
For compound 4 the middle estimate is 5 percentage points below the measured one; low and high end bracket the measured number.
By their numbers in this assay, from the lowest: compounds 3 and 2 (each within the scatter of the next); then compound 4; then compound 1.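

In this assay, within the data shown here, the change on this oxygen gives a number 12 percentage points lower from compound 1 to compound 4 (beyond the scatter), the first measured step at this place on the molecule. A single methyl can thus give way to 3-nitrophenyl, a much larger group with its own aromatic ring, and compound 4 still shows 53%, so growth inhibition is lowered but not lost. Nothing available explains this fall in inhibition.

This single step cannot show whether the change in the number follows from the added aromatic ring, from the nitro group on it, or from both together, and a plain phenyl or a 3-aminophenyl on the same oxygen would help to separate these possibilities. It also leaves open how the number responds to other kinds of group here, such as a longer carbon chain like butyl or a chain ending in a carboxylic acid, and whether the position on the aromatic ring that carries the nitro group matters at all.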